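This account rests on a few compounds, and the source may have more. Where it says the series, first, only, none or still open, it means among the compounds named here.

In a physicochemical assay for permeability, using PAMPA, at pH 7.4 (a lower number here means that the compound crosses the layer more slowly, a higher number that the compound crosses the layer faster), compound 1 `CS(=O)(=O)NC(=O)c1ccc(Nc2nc(NC3(c4ccc(Cl)cc4)CC3)nc(OCC(F)(F)F)n2)cc1` gives 11 nm/s. Compound 2 `COC(=O)NCCS(=O)(=O)NC(=O)c1ccc(Nc2nc(NC3(c4ccc(Cl)cc4)CC3)nc(OCC(F)(F)F)n2)cc1` gives 39 nm/s, and compound 3 `O=C(NS(=O)(=O)CCNCc1ccccc1)c1ccc(Nc2nc(NC3(c4ccc(Cl)cc4)CC3)nc(OCC(F)(F)F)n2)cc1` gives 49 nm/s; both carry a substituent on a saturated chain carbon bound to a sulfonyl sulfur, with a 3.5-fold higher number from compound 1 to compound 2 (0.55 log units; beyond the scatter) and a 4.5-fold higher number from compound 1 to compound 3 (0.65 log units; beyond the scatter). Compound 3 is separated beyond the scatter only from compound 1, since the remaining step of a 1.3-fold higher number from compound 2 to compound 3 (0.10 log units; within the scatter) lies within the scatter. Compound 4 `CC(C)NCCS(=O)(=O)NC(=O)c1ccc(Nc2nc(NC3(c4ccc(Cl)cc4)CC3)nc(OCC(F)(F)F)n2)cc1` differs from compound 3 by isopropyl in place of benzyl on an amine nitrogen. Within the data shown here, the one measured change at the same amine nitrogen, a 1.3-fold higher number from compound 2 to compound 3 (0.10 log units; within the scatter), stayed within the scatter, so no step beyond the scatter is anticipated in this assay. Compound 4 is therefore expected to give about 40 nm/s, within a range of 20 nm/s to 80 nm/s. The expected step of a 1.2-fold lower number from compound 3 to compound 4 (0.09 log units; within the scatter) is accordingly small.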

Compound 4, apparent permeability: 45 nm/s
Compound 4: middle estimate off by 1.1-fold (0.05 log units), on the low side, within the range that was stated.
By their numbers in this assay, from the lowest: compound 1; then compounds 2, 4 and 3 (each within the scatter of the next).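

In this assay the amine nitrogen now carries three different groups with no separation beyond the scatter: isopropyl in place of benzyl gives a 1.1-fold lower number from compound 3 to compound 4 (0.04 log units; within the scatter) and isopropyl in place of methoxycarbonyl gives a 1.2-fold higher number from compound 2 to compound 4 (0.06 log units; within the scatter) even though isopropyl has no ring. The gain over the hydrogen on the saturated chain carbon remains with the third group, at a 4.1-fold higher number from compound 1 to compound 4 (0.61 log units; beyond the scatter) and so beyond the scatter. No measurement here accounts for these numbers. Open, going by these compounds, is whether a primary amine, a tertiary amine or a carboxylic acid at this place, or a longer chain, would stay within the same scatter.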